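Naphthyl Hydrazone in Place of Chlorophenyl on the Shared Core

The source may hold more compounds than are shown below. What is called first, only, known or untested is meant among the compounds shown, and "the series" means these compounds.

Compound 2 `CCCSc1nc(N/N=C/c2ccc(Cl)cc2)c2nnn(Cc3ccccc3)c2n1` was tested in a functional assay on MCF7 cells (Homo sapiens) for antiproliferative activity, read by MTT assay, with a stated time of 72 h; on this read-out lower numbers stand for stronger inhibition and higher numbers for weaker inhibition. In this assay compound 2 gives > 64000 nM, which is a limit of the assay and not a number. Compound 1 `CCCSc1nc(N/N=C(\C)c2ccccc2O)c2nnn(Cc3ccccc3Cl)c2n1` likewise gives only a limit, > 64000 nM. Compound 3 `CCCSc1nc(N/N=C(\C)c2ccc(O)cc2)c2nnn(Cc3ccccc3)c2n1` gives 21600 nM. For the measured compounds named here, the one readable step, an at least 2.9-fold lower number from compound 2 to compound 3 (0.47 log units; beyond the scatter), shows a different replacement at that end of the molecule moving the value off the limit.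

Compound 4 `CCCSc1nc(N/N=C/c2ccc3ccccc3c2)c2nnn(Cc3ccccc3)c2n1` differs from compound 2 by naphthalen-2-yl in place of 4-chlorophenyl on a carbon with a double bond to nitrogen. Going by the values given here, no measured step matches this change, and compound 2 sits at the limit of > 64000 nM in this assay, at which 2 of the 3 values shown sit, so only a gain could register. Compound 4 is expected near 50000 nM, within 15000 nM to 150000 nM. That estimate means a step of an at least 1.2-fold lower number from compound 2 to compound 4 (0.10 log units; that floor lies within the scatter), which is expected to stay within the scatter.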

Compound 4, half-maximal inhibitory concentration: > 64000 nM
Compound 4 was reported as a limit (the forecaster's own chance of this, stated with the estimate: 55%); middle value at least 1.2-fold (0.10 log units) away from the limit.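

Compound 2 and compound 4 each give only a limit of the assay, not a number, so no step can be read between them: the limit of > 64000 nM in this assay, at which 3 of the 4 values shown sit. From the compounds shown here alone, how naphthalen-2-yl truly compares with 4-chlorophenyl on the shared core stays open.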